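This account rests on a few compounds, and the source may have more. Where it says the series, first, only, none or still open, it means among the compounds named here.

Compound 1 `CN(Cc1ccccc1)C(=O)c1cc2c(Cc3ccccc3)n[nH]c2cc1O` gives 980 nM in a functional assay on A2780 cells (Homo sapiens) for antiproliferative activity, read by resazurin assay, with a stated time of 72 h; a higher number here means a weaker inhibitor, a lower number a stronger inhibitor. Compound 2 `Cc1cccc(CN(C)C(=O)c2cc3c(Cc4ccccc4)n[nH]c3cc2O)c1` is reported as "not determined" (no result reported) in this assay, so it stands on no number of its own, and only compound 1 offers a value nearby. Compound 3 `CCc1ccc(CN(C)C(=O)c2cc3c(Cc4ccccc4)n[nH]c3cc2O)cc1` differs from compound 2 in one place: 4-ethylphenyl in place of 3-methylphenyl on a saturated chain carbon bound to an amide-type nitrogen. Going by the values given here, no measured step joins these two compounds; a change of this kind is expected to move the result in this assay by no more than the usual scatter, in no firm direction. Taking the result of compound 1, 980 nM, as the only anchor, compound 3 is expected to give about 1000 nM, within 300 nM to 3500 nM.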

Compound 3, half-maximal inhibitory concentration: 9400 nM
Beside the measured number, compound 3's estimate is 9.4-fold (0.97 log units) below it, and the stated range ends below it.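

In this assay, ethyl in place of hydrogen on an aromatic carbon gives a 9.6-fold higher number from compound 1 to compound 3 (0.98 log units; beyond the scatter), the first sign that a small addition to the aryl group on this saturated chain carbon can weaken the result beyond the scatter. The step from compound 2 to compound 3 cannot be read, as compound 2 has no number. Nothing available here accounts for the rise. Still open, from the compounds shown here alone, is whether a methyl, a methoxy or an amine on that aromatic ring would weaken the result as ethyl does.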